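From bromo to iodo: compound 2 to compound 3

This account rests on a few compounds, and the source may have more. Where it says the series, first, only, none or still open, it means among the compounds named here.

Within the data shown here, in a functional assay on HCT-15 cells (Homo sapiens) for inhibition, read by sulforhodamine B assay, with a stated time of 48 h (on this read-out lower numbers stand for stronger inhibition of growth and higher numbers for weaker inhibition of growth), compound 2 (`NC(=O)c1cc(Br)ccc1NC(=O)/C=C/c1ccccc1`) gives 1040 nM as the lower of the two numbers so far, and compound 1 (`Cc1ccc(NC(=O)/C=C/c2ccccc2)c(C(N)=O)c1`) gives 3770 nM on the same read-out. Compound 3 (`NC(=O)c1cc(I)ccc1NC(=O)/C=C/c1ccccc1`) is not yet measured. It carries iodo in place of bromo on an aromatic carbon, meta to a carbamoyl group and para to a large group. Among the measured compounds shown here, only one measured step bears on this change, bromo in place of methyl on that same carbon: a 3.6-fold lower number from compound 1 to compound 2 (0.56 log units; beyond the scatter) is modest but beyond the scatter. That is a single pair and a different exchange, so it points only weakly to a further small drop in this assay on going to iodo. The expected step is a 1.3-fold lower number from compound 2 to compound 3 (0.11 log units; within the scatter) and may well not clear the scatter. For compound 3 the estimated value is 800 nM (expected range 350 nM to 1900 nM).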

Compound 3, concentration for 50% growth inhibition: 586 nM
Compound 3: the middle estimate sits 1.4-fold (0.14 log units) above what was measured; low and high end bracket the measured number.
By their numbers in this assay, from the lowest: compounds 3 and 2 (each within the scatter of the next); then compound 1.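

Iodo in place of bromo on this aromatic carbon, meta to a carbamoyl group and para to a large group, reads in this assay as a 1.8-fold lower number from compound 2 to compound 3 (0.25 log units; within the scatter), so the two halogens cannot be told apart here. Iodo in place of methyl at the same carbon reads as a 6.4-fold lower number from compound 1 to compound 3 (0.81 log units; beyond the scatter), and with a 3.6-fold lower number from compound 1 to compound 2 (0.56 log units; beyond the scatter) this gives two halogens that both stand clear of methyl, a larger step for iodo being no firm ranking of the two. Nothing measured here explains the difference from methyl.

Going by these compounds, whether chloro or fluoro on this carbon would fall with bromo and iodo or with methyl remains open, as does the outcome with an amine or a methoxy group there. Also open, on these data alone, is whether the halogen step holds with a carboxylic acid in place of the carbamoyl group.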